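Methyl for Trifluoromethyl on a Benzyl Thioether

The source may hold more compounds than are shown below. What is called first, only, known or untested is meant among the compounds shown, and "the series" means these compounds.

Three compounds share one core and differ only in the group carried on the sulfur. In a functional assay on KBVIN cells (Homo sapiens) for antiproliferative activity, read by sulforhodamine B assay, with a stated time of 72 h (on this read-out lower numbers stand for stronger inhibition of growth and higher numbers for weaker inhibition of growth), compound 1 `Cc1cc(=O)oc2cc(Sc3cccc(Cl)n3)ccc12` gives 920 nM. Compound 2 `Cc1cc(=O)oc2cc(SC3CCOC3=O)ccc12` reaches only a limit in this assay, namely > 36100 nM. Compound 3 `Cc1cc(=O)oc2cc(SCc3cccc(C(F)(F)F)c3)ccc12` likewise reaches only a limit in this assay, namely > 28500 nM. Two of the three values shown are limits: compound 3 sits at the limit of > 28500 nM in this assay, at which 1 of the 3 values shown sits, and compound 2 at the limit of > 36100 nM in this assay, at which 1 of the 3 values shown sits, so compound 3 stands among the compounds for which no number was obtained, and compound 1 alone carries a measured value.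

Compound 4 `Cc1cccc(CSc2ccc3c(C)cc(=O)oc3c2)c1` is not yet measured. It differs from compound 3 by methyl in place of trifluoromethyl on an aromatic carbon. No step between measured compounds is shown, so no measured size exists for a change of this kind. Within the data shown here, the only compound with a number, compound 1, carries a different kind of group on the sulfur, and compound 3 itself gives no number. Compound 4 is therefore expected to return a limit as well, with an estimated 30000 nM in this assay and a range from 8000 nM to 100000 nM. The step that the limit leaves unreadable from compound 3 to compound 4 is accordingly estimated as none beyond the scatter.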

Compound 4, concentration for 50% growth inhibition: > 33700 nM
Compound 4 ended at the assay's limit; the forecaster's own chance of this, stated with the estimate: 70%; middle value at least 1.1-fold (0.05 log units) away from the limit.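

Compound 3 and compound 4 both end at a limit in this assay, so the step between them, methyl in place of trifluoromethyl on an aromatic carbon, cannot be read. The compounds shown leave open whether these two groups differ at all in their effect on growth in this assay, as neither compound gives a number.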